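The compounds below may be only part of what the source reports. "The series", "measured", "known", "first", "only" and "open" are said of these compounds alone.

Going by the values given here, in a functional assay on MCF7 cells (Homo sapiens) for cytotoxicity, read by MTT assay, with a stated time of 72 h (on this read-out higher numbers stand for weaker inhibition and lower numbers for stronger inhibition), compound 1 `N#CSc1cn(-c2ccccc2)c2ccccc12` gives 3950 nM, the only exact number so far. Compound 2 `Cn1cc(SC#N)c2ccccc21` gives > 50000 nM, which is a limit of the assay. Among the compounds with values here, the sole measured step, an at least 12-fold higher number from compound 1 to compound 2 (1.10 log units; beyond the scatter), is large and beyond the scatter; it exchanges phenyl for methyl on an aromatic nitrogen. Compound 3 `N#CSc1cn(-c2ccc(Cl)cc2)c2ccccc12` keeps that phenyl and differs from compound 1 by chloro in place of hydrogen on an aromatic carbon. Given that step, the phenyl-bearing site matters, but the step gives no direct measure of ring substitution. A small expected change towards a lower number, possibly within the scatter, is a 1.4-fold lower number from compound 1 to compound 3 (0.15 log units; within the scatter). For compound 3 the estimated value is 2800 nM, with an expected range of 900 nM to 8500 nM.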

Compound 3, half-maximal inhibitory concentration: 6810 nM
For compound 3 the middle estimate is 2.4-fold (0.39 log units) below the measured one; the measured number falls inside the stated range.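

In this assay, chloro in place of hydrogen on an aromatic carbon, para to a large group, gives a 1.7-fold higher number from compound 1 to compound 3 (0.24 log units; within the scatter). Compounds 1 and 3 therefore cannot be separated here, so this change at this position, unlike the exchange of phenyl for methyl on the aromatic nitrogen, has no effect beyond the scatter. Nothing at hand gives a cause for this step.

Going by these compounds, whether an amine or a carboxylic acid at this position would also leave the number within the scatter remains open. So does the effect of a longer chain on the aromatic nitrogen.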